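One Ring Swap on a Weak Antiproliferative Compound

This account rests on a few compounds, and the source may have more. Where it says the series, first, only, none or still open, it means among the compounds named here.

Compound 1 `O=c1cc[nH]c(=O)n1C1CN(S(=O)(=O)c2ccccc2[N+](=O)[O-])c2ccccc2CO1`: 50900 nM
Compound 2 `Clc1ncnc2c1ncn2C1CSc2ccccc2CO1`: 1250 nM

Both numbers come from a functional assay on MCF7 cells (Homo sapiens) for antiproliferative activity; on this read-out higher numbers stand for weaker inhibition and lower numbers for stronger inhibition. Compound 1 stands at the higher of the two numbers, and compound 2 sits at a number far lower, beyond the scatter, though the two compounds share no single point of difference and their cores are not the same.

Compound 3 `O=[N+]([O-])c1ccccc1S(=O)(=O)N1CC(n2cnc3ncnc(O)c32)OCc2ccccc21` is built from compound 1 by one change: a group of 10 heavy atoms (5 carbon, 4 nitrogen, 1 oxygen; one five-membered aromatic ring with 2 hetero atoms, one six-membered aromatic ring with 2 hetero atoms) in place of a group of 8 heavy atoms (4 carbon, 2 nitrogen, 2 oxygen; one six-membered aromatic ring with 2 hetero atoms), on a saturated ring carbon. For the measured compounds named here, the group that enters resembles the aromatic group carried by compound 2, which gives the lower number, so a step toward a lower number in this assay is expected, though the core of compound 3 remains that of compound 1 and no direct step supports the size. The expected step is a 3.4-fold lower number from compound 1 to compound 3 (0.53 log units; beyond the scatter). For compound 3 the estimated value is 15000 nM, within a range from 3000 nM to 60000 nM.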

Compound 3, half-maximal inhibitory concentration: 19700 nM
Compound 3: the middle estimate sits 1.3-fold (0.12 log units) below what was measured, within the range that was stated.
By their numbers in this assay, from the lowest: compound 2; then compound 3; then compound 1.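

In this assay, the change gives a 2.6-fold lower number from compound 1 to compound 3 (0.41 log units; beyond the scatter) and this step is rated modest. For the compounds shown here, it is the first direct reading at this position, on the saturated ring carbon next to the ring oxygen: with the core of compound 1 held fixed, the group with a five-membered and a six-membered aromatic ring gives a lower number than the group with a single six-membered aromatic ring. No measurement shown here explains this difference.

Going by these compounds alone, compound 2 differs from compound 3 in more than one place, so no step between them can be read, and the separate contributions of the core and the group remain unknown. Also open, as far as these compounds go, is how the number would respond if the oxygen on the entering group were replaced by an amine.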